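The source may report more compounds than this note shows. Statements on the series, on what has been measured and on what is new or still open speak of the compounds shown alone.

Series notes. Compound 1 `ClCc1ccccc1Cn1cnc2c(Cl)nc(Cl)nc21` and compound 2 `ClCc1cccc(Cn2cnc3c(Cl)nc(Cl)nc32)c1` have the same atoms joined differently; the difference between the two cores is not broken down here. In a functional assay on CAKI-1 cells (Homo sapiens) for cytotoxicity, read by sulforhodamine B assay, with a stated time of 48 h (a higher number here means a weaker inhibitor of growth, a lower number a stronger inhibitor of growth), compound 1 gives 360 nM, and compound 2 gives 2230 nM. Compound 3 `Nc1nc(Cl)c2ncn(Cc3ccccc3CCl)c2n1` is compound 1 with amino in place of chloro on an aromatic carbon; in this assay compound 3 gives 6610 nM, so the step is an 18-fold higher number from compound 1 to compound 3 (1.26 log units; beyond the scatter). Compound 4 `Nc1nc(Cl)c2ncn(Cc3cccc(CCl)c3)c2n1` is not yet measured; it is compound 2 with amino in place of chloro on an aromatic carbon, the same change in the same place as the one taking compound 1 to compound 3, and this change is made in two pairs among these compounds. Compound 2 already gives a higher number than compound 1 and a lower one than compound 3 in this assay. Within the data shown here, for compound 4 the expected step is an 11-fold higher number from compound 2 to compound 4 (1.05 log units; beyond the scatter), somewhat smaller than the measured one, resting on the single step of an 18-fold higher number from compound 1 to compound 3 (1.26 log units; beyond the scatter) transferred to a different core; one precedent is thin ground. Compound 4 is therefore estimated at 25000 nM in this assay, with a range from 8000 nM to 80000 nM.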

Compound 4, concentration for 50% growth inhibition: 240 nM
Compound 4: the middle estimate sits 100-fold (2.02 log units) above what was measured, outside the stated range (below it).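

In this assay, amino in place of chloro on an aromatic carbon gives a 9.3-fold lower number from compound 2 to compound 4 (0.97 log units; beyond the scatter), so on the core of compound 2 the change lowers the number instead of raising it. A result from the core of compound 1 therefore gives no usable forecast for this change on the core of compound 2, in size or in direction. With only one pair on each core, the series does not show which core's step is more typical, or which structural difference between the cores accounts for the split, only that the two steps disagree: the same change on two cores in this assay, an 18-fold higher number (1.26 log units; beyond the scatter) from compound 1 to compound 3 and a 9.3-fold lower number (0.97 log units; beyond the scatter) from compound 2 to compound 4, 170-fold (2.23 log units) apart, beyond the scatter of two such steps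

Open questions are whether a methoxy group or a dimethylamino group in the same place would also split between the two cores, and whether such a split would be limited to amino. On these data alone, it also remains open whether the reversal would persist with hydroxymethyl in place of chloromethyl on either core.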